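The source may report more compounds than this note shows. Statements on the series, on what has been measured and on what is new or still open speak of the compounds shown alone.

Measured compounds in a functional assay on L1210 cells (Mus musculus) for cytotoxicity; on this read-out higher numbers stand for weaker inhibition and lower numbers for stronger inhibition:

compound 1 `O=C(/C=C/C(=O)N1C/C(=C\c2ccccc2)C(=O)/C(=C/c2ccccc2)C1)Nc1ccccc1` gives 3600 nM
compound 2 `Cc1ccc(NC(=O)/C=C/C(=O)N2C/C(=C\c3ccc([N+](=O)[O-])cc3)C(=O)/C(=C/c3ccc([N+](=O)[O-])cc3)C2)cc1C` gives 4900 nM
compound 3 `COc1ccc(NC(=O)/C=C/C(=O)N2C/C(=C\c3ccc([N+](=O)[O-])cc3)C(=O)/C(=C/c3ccc([N+](=O)[O-])cc3)C2)cc1` gives 2900 nM

Compound 2 holds the highest of the three numbers, but both neighbours sit within the scatter of it: compound 1 is the nearest, compound 3 the furthest, and neither gap counts as a real difference on this read-out.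

Compound 4 `O=C(/C=C/C(=O)N1C/C(=C\c2ccc([N+](=O)[O-])cc2)C(=O)/C(=C/c2ccc([N+](=O)[O-])cc2)C1)Nc1ccc(Cl)cc1` keeps the core of compound 2 and differs in one place: 4-chlorophenyl in place of 3,4-dimethylphenyl on an amide-type nitrogen.

For the measured compounds named here, only one measured step bears on this change, and it concerns the same place: a 1.7-fold lower number from compound 2 to compound 3 (0.23 log units; within the scatter). That exchange of one aryl group on the amide-type nitrogen for another left the number unmoved within the scatter. Going by the values given here, no measured step touches the 4-chlorophenyl group itself, so its own effect is unknown; the one comparison available at this position points to little change. The step from compound 2 to compound 4 is therefore expected to stay within the scatter, a 1.2-fold lower number from compound 2 to compound 4 (0.09 log units; within the scatter).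

Compound 4 is expected to give about 4000 nM in this assay, with a range of 2000 nM to 8000 nM.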

Compound 4, half-maximal inhibitory concentration: 3600 nM
Compound 4: middle estimate off by 1.1-fold (0.05 log units), on the high side; low and high end bracket the measured number.
By their numbers in this assay, from the lowest: compounds 3, 1, 4 and 2 (each within the scatter of the next).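

In this assay, for the compounds shown here, the amide-type nitrogen now carries a third aryl group without a step beyond the scatter: 4-chlorophenyl in place of 3,4-dimethylphenyl gives a 1.4-fold lower number from compound 2 to compound 4 (0.13 log units; within the scatter) and extends the single earlier comparison at this position. The new pair of compound 3 and compound 4 tests chloro in place of methoxy on an aromatic carbon and gives a 1.2-fold higher number from compound 3 to compound 4 (0.09 log units; within the scatter), so this exchange also leaves the numbers indistinguishable. No measurement at hand explains this flat stretch of the series.

All three aryl groups compared here are substituted phenyl rings carrying only methyl, methoxy or chloro groups. From the compounds shown here alone, whether a carboxylic acid or an amine on that ring, or a longer alkyl chain in place of the ring, would move the number beyond the scatter remains open.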